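Ortho-Halogen Swap in an Oxazoline Ether Series

The compounds below may be only part of what the source reports. "The series", "measured", "known", "first", "only" and "open" are said of these compounds alone.

Three compounds built on a shared core have been run through a functional assay on the whole organism for inhibition, with Rattus norvegicus as the target, read by paw edema, with a stated time of 30 min, at a dose of 40 mg/kg by the oral route; on this read-out higher numbers stand for a stronger effect at the one dose given and lower numbers for a weaker effect. Compound 1 `COc1ccc(OCC2=NCCO2)cc1` gives 33.2%, compound 2 `Brc1ccccc1OCC1=NCCO1` gives 29.1%, and compound 3 `Cc1cccc(OCC2=NCCO2)c1` gives 44.6%. Of the three numbers, compound 2 has the lowest. Its nearest neighbour is compound 1, whose number lies within the usual scatter of compound 2's, so nothing separates the two; compound 3 is the furthest, and its gap above compound 2 lies beyond the scatter.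

Compound 4 `Fc1ccccc1OCC1=NCCO1` has not yet been measured in this assay. It differs from compound 2 in one place: fluoro in place of bromo on an aromatic carbon. The group that leaves and the group that enters are each a single heavy atom, and the change sits ortho to a group of 7 heavy atoms on the carbon-only six-membered aromatic ring.

Within the data shown here, no measured pair in this set shows what swapping one halogen for another does here, so there is no step to lean on. With the small change involved, the expected step of a number 3.9 percentage points higher from compound 2 to compound 4 (within the scatter) is one that stays within the scatter, with no clear direction. Compound 4 is therefore expected to give about 33%, in a range from 18% to 48%.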

Compound 4, a percentage reported as inhibition, in the whole organism at one dose (the size of the read-out at that dose, not a potency): 30.5%
Beside the measured number, compound 4's estimate is 2.5 percentage points above it; measured number inside the range.
By their numbers in this assay, from the lowest: compounds 2, 4 and 1 (each within the scatter of the next); then compound 3.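

The pair gives this series its first step in this assay and shows that fluoro in place of bromo on an aromatic carbon, ortho to a group of 7 heavy atoms, amounts to a number 1.4 percentage points higher from compound 2 to compound 4 (within the scatter) and so separates nothing. Among these compounds, at this one position, then, the read-out at the single oral dose does not tell these two halogens apart, even though earlier there was no measured pair that could speak to such a swap. Nothing shown here accounts for this outcome or links it to any property of either halogen.

What the compounds shown leave open is whether a different kind of group on this same aromatic carbon, such as an amine, a carboxylic acid or a longer chain, would move the number beyond the scatter, and whether the bromo and fluoro exchange would look the same elsewhere on the ring. Compound 1 and compound 3 differ from this pair in more than one place, so they cannot settle either question, and the gap of compound 3 above compound 2 remains unexplained.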